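Solubility of a Serine-Derived Hydroxamate and Its Amine Analogue

The compounds below may be only part of what the source reports. "The series", "measured", "known", "first", "only" and "open" are said of these compounds alone.

Measured compounds:
- Compound 1 `C#CCNC(=O)C[C@H](NC(=O)c1ccc(C#Cc2ccccc2)cc1)C(=O)NO`: 8000 nM
- Compound 2 `CSC[C@H](NC(=O)c1ccc(C#Cc2ccccc2)cc1)C(=O)NO`: 2000 nM
- Compound 3 `O=C(N[C@H](CO)C(=O)NO)c1ccc(C#Cc2ccccc2)cc1`: 36000 nM

In a physicochemical assay for solubility (on this read-out higher numbers stand for higher solubility and lower numbers for lower solubility), compound 3 gives the highest of the three numbers, with compound 1 at 8000 nM and compound 2 at 2000 nM behind it. Compound 4 `NC[C@H](NC(=O)c1ccc(C#Cc2ccccc2)cc1)C(=O)NO` differs from compound 3 in one place: a group of 7 heavy atoms (3 carbon, 2 nitrogen, 2 oxygen; no ring) in place of a group of 7 heavy atoms (3 carbon, 1 nitrogen, 3 oxygen; no ring), on an amide-type nitrogen. For the measured compounds named here, the steps that bear on this position are a 4.0-fold lower number from compound 1 to compound 2 (0.60 log units; beyond the scatter) and an 18-fold higher number from compound 2 to compound 3 (1.26 log units; beyond the scatter), both changes on the same amide-type nitrogen, one modest and one large. Neither swaps in the group that enters here, so the direction is uncertain; the expected step is small, a 1.1-fold higher number from compound 3 to compound 4 (0.05 log units; within the scatter), well within the span of the measured numbers. Compound 4 is therefore estimated at 40000 nM, with a range from 15000 nM to 120000 nM.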

Compound 4, solubility: 13000 nM
The estimate for compound 4 lay 3.1-fold (0.49 log units) above the measured number; the measured number lies below the stated range.
By their numbers in this assay, from the lowest: compound 2; then compounds 1 and 4 (each within the scatter of the next); then compound 3.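

In this assay, two groups that tally alike in heavy atoms, hydrogen-bond donors and acceptors still give different numbers at this position (a 2.8-fold lower number from compound 3 to compound 4 (0.44 log units; beyond the scatter)). Amino also separates from methylsulfanyl (a 6.5-fold higher number from compound 2 to compound 4 (0.81 log units; beyond the scatter)), but not from propargylcarbamoyl (a 1.6-fold higher number from compound 1 to compound 4 (0.21 log units; within the scatter)). No measurement here explains these differences. On these data alone, whether a carboxylic acid or a longer chain ending in an amine would reach the number of compound 3 remains open.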